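Ortho substituent swap on the quinazolinone topoisomerase series

A few compounds are considered here, and "the series" means these few. Any claim that something is new, unique, unknown or untested is made for them only; others in the source may bear on it.

Measured compounds:
- compound 1 `Cc1ccc2c(=O)[nH]c(-c3ccccc3N(C)C)nc2c1`: 82.1%
- compound 2 `Cc1ccc2nc(-c3ccccc3C(F)(F)F)[nH]c(=O)c2c1`: 72%
- compound 3 `Cc1cccc(-c2nc3ccc(C)cc3c(=O)[nH]2)c1`: 75.7%

All three were tested in an assay on isolated protein for inhibition of DNA topoisomerase 1 (Homo sapiens), with a stated time of 30 min, tested at 100 uM; on this read-out lower numbers stand for a weaker effect and higher numbers for a stronger effect at the one concentration tested. In this assay compound 1 gives 82.1%, the highest of the three numbers. The nearest is compound 3, whose read-out sits within the usual scatter of that of compound 1, so no order between these two can be claimed. Compound 2 lies further off, beyond the scatter, and is the only one of the set whose number is clearly lower than that of compound 1.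

The next compound is compound 4 `Cc1ccc2c(=O)[nH]c(-c3ccccc3C)nc2c1`, not yet measured in this assay. Against compound 1 the change is methyl in place of dimethylamino on an aromatic carbon. The group that leaves is the larger one; the group that enters is a single carbon.

Among the compounds with values here, no step between two measured compounds isolates this change, so the expectation leans on the spread of the three numbers, which is narrow. The step from compound 1 to compound 4 is expected to be small and downward, with a number 8.1 percentage points lower from compound 1 to compound 4 (within the scatter), and may well fall within the scatter. For compound 4 the estimate is 74%, with a range from 58% to 88%.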

Compound 4, a percentage reported as inhibition, at one concentration (the size of the read-out at that concentration, not a potency): 100%
For compound 4 the middle estimate is 26 percentage points below the measured one; measured number above the stated range.
By their numbers in this assay, from the lowest: compounds 2, 3 and 1 (each within the scatter of the next, the first and the last beyond it); then compound 4.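

In this assay, within the data shown here, the step of a number 17.9 percentage points higher from compound 1 to compound 4 (beyond the scatter) is the first one that isolates a single change, and it shows that the substituent at this place, on an aromatic carbon ortho to a large group, affects the read-out. Dimethylamino is not needed to keep the effect at the one concentration tested: methyl, with fewer heavy atoms and no hydrogen-bond acceptor, gives compound 4 a read-out of 100% in this assay on the same core. No supporting measurement bears on the reason for this step.

Among these compounds, the single step changes heavy-atom count and hydrogen-bond acceptor count together, so the two cannot be separated; ethyl, methoxy or a primary amine at the same place would be needed to tell them apart. From the compounds shown here alone, the read-out also comes from one concentration and gives no potency, so how far compound 4 stands from compound 1 in potency remains open.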